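The source may hold more compounds than are shown below. What is called first, only, known or untested is meant among the compounds shown, and "the series" means these compounds.

Compound 1 `O=C(NCc1ccc(F)cc1)c1nc[nH]c1C(=O)O` in an ADME assay on MT4 cells (Homo sapiens) for cytotoxicity (a lower number here means that less compound is tolerated, a higher number that more compound is tolerated), gives > 20000 nM, which is a limit of the assay rather than a number.
Compound 2 `O=C(Nc1ccc([N+](=O)[O-])cc1)c1nc[nH]c1C(=O)O` in this assay gives > 20000 nM, likewise a limit of the assay.

Going by the values given here, compound 2 therefore stands at the same limit as the one other value shown: the limit of > 20000 nM in this assay, at which 2 of the 2 values shown sit. Among the compounds with values here, because both values are limits, no step between measured compounds can be sized, and nothing in the data points to a difference between compound 1 and compound 2 in this assay.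

Compound 3 `Nc1ccc(NC(=O)c2nc[nH]c2C(=O)O)cc1` carries amino in place of nitro on an aromatic carbon. With only limits to go on, the step from compound 2 to compound 3 in this assay is expected to be none beyond the scatter, and compound 3 is expected most likely to sit at the limit once more. Compound 3 in this assay is estimated at 30000 nM, within a range from 12000 nM to 80000 nM. That estimate means an expected step that the limit leaves unreadable from compound 2 to compound 3.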

Compound 3, half-maximal cytotoxic concentration: > 20000 nM
Compound 3 was reported as a limit; the forecaster's own chance of this, stated with the estimate: 85%; the middle value does not contradict the limit.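

In this assay compound 2 and compound 3 both stand at a limit rather than a number, so no step can be read for amino in place of nitro on an aromatic carbon: the limit of > 20000 nM in this assay, at which 3 of the 3 values shown sit.

The compounds shown leave open how far any of them lies from that limit, and whether any change to the shared core would move a compound off it.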